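The source may hold more compounds than are shown below. What is called first, only, known or untested is meant among the compounds shown, and "the series" means these compounds.

Three compounds share one core and differ only in the group carried on an amine nitrogen in a ring. Compound 1 `O=C(c1ccccc1)N1CCC(NS(=O)(=O)c2cc(S(=O)(=O)c3ccccc3)ccc2C(F)(F)F)CC1` gives in an assay on isolated protein for displacement of a labelled ligand from secreted frizzled-related protein 1 (Homo sapiens), read by fluorescence polarization, with a stated time of 30 min (a lower number here means a stronger inhibitor, a higher number a weaker inhibitor), a value of 70 nM. Compound 2 `O=C(O)c1ccc(N2CCC(NS(=O)(=O)c3cc(S(=O)(=O)c4ccccc4)ccc3C(F)(F)F)CC2)cc1` gives 120 nM in this assay, a step of a 1.7-fold higher number from compound 1 to compound 2 (0.23 log units; within the scatter). Compound 3 `CC(C)(C)OC(=O)N1CC[C@H](C(=O)N2CCC(NS(=O)(=O)c3cc(S(=O)(=O)c4ccccc4)ccc3C(F)(F)F)CC2)C1` gives 70 nM in this assay, a step of no change at the digits printed from compound 1 to compound 3 (within the scatter). On these numbers compound 3 stands level with compound 1, the two together at the lowest numbers shown, and compound 2 lies within the scatter of both.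

Compound 4 `O=C([C@@H]1CCNC1)N1CCC(NS(=O)(=O)c2cc(S(=O)(=O)c3ccccc3)ccc2C(F)(F)F)CC1` differs from compound 3 by pyrrolidin-3-yl in place of 1-(tert-butoxycarbonyl)pyrrolidin-3-yl on a carbonyl carbon. Among the compounds with values here, the two measured steps that touch this part of the molecule both stayed within the scatter, so nothing measured so far argues for a large change here. The estimate for compound 4 in this assay is therefore 100 nM, with a range from 35 nM to 300 nM. This corresponds to an expected step of a 1.4-fold higher number from compound 3 to compound 4 (0.15 log units; within the scatter), which is not expected to reach beyond the scatter.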

Compound 4, half-maximal inhibitory concentration: 60 nM
For compound 4 the middle estimate is 1.7-fold (0.22 log units) above the measured one; measured number inside the range.
By their numbers in this assay, from the lowest: compounds 4, 1, 3 and 2 (each within the scatter of the next).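

On the carbonyl carbon, pyrrolidin-3-yl, with 5 heavy atoms and 1 hydrogen-bond donor, replaces 1-(tert-butoxycarbonyl)pyrrolidin-3-yl, with 12 heavy atoms and 0 hydrogen-bond donors, and this assay records a 1.2-fold lower number from compound 3 to compound 4 (0.07 log units; within the scatter), so a much smaller group with a ring amine hydrogen is accommodated here. Set against phenyl on the same carbonyl carbon the result is a 1.2-fold lower number from compound 1 to compound 4 (0.07 log units; within the scatter), and set against 4-carboxyphenyl on the amine nitrogen in a ring it is a 2.0-fold lower number from compound 2 to compound 4 (0.30 log units; within the scatter), which extends the range of groups on this position that remain within the scatter. No measurement given here accounts for this tolerance.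

On these data alone, it remains open whether a carboxylic acid or a longer alkyl chain on the pyrrolidine nitrogen would also stay within the scatter. As far as these compounds go, the opposite arrangement at the stereocentre of pyrrolidin-3-yl also remains open.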